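A few compounds are considered here, and "the series" means these few. Any claim that something is new, unique, unknown or untested is made for them only; others in the source may bear on it.

Within the data shown here, in a functional assay on HT-29 cells (Homo sapiens) for antiproliferative activity, read by MTT assay, with a stated time of 48 h (a lower number here means a stronger inhibitor of growth, a higher number a weaker inhibitor of growth), compound 1 `COC(=O)N1N=C(c2cccc(OC)c2)CC1c1cc(OC)c(OC)c(OC)c1` gives 1300 nM, the only true number so far. Compound 2 `CCCOC(=O)N1N=C(c2cccc(OC)c2)CC1c1cc(OC)c(OC)c(OC)c1` reads > 10000 nM, which is a limit. Compound 3 `COc1cccc(C2=NN(C(=O)OCc3ccccc3)C(c3cc(OC)c(OC)c(OC)c3)C2)c1` reads > 10000 nM, also a limit. Compound 1 is therefore the only one of the three with a measured potency, and both measured steps away from it lead to much weaker growth inhibition. Both steps enlarge the ester: the first gives an at least 7.6-fold higher number from compound 1 to compound 2 (0.88 log units; beyond the scatter), and the second gives an at least 7.6-fold higher number from compound 1 to compound 3 (0.88 log units; beyond the scatter).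

Compound 4 `COC(=O)N1N=C(c2cccc(C)c2)CC1c1cc(OC)c(OC)c(OC)c1` keeps the ester of compound 1 and changes another place: methyl in place of methoxy on an aromatic carbon. In words, this puts methyl in place of methoxy on an aromatic carbon. Among the measured compounds shown here, no measured step covers this change, so the large ester steps cannot be carried over, and the expectation starts from compound 1 at 1300 nM. No step beyond the scatter is expected in this assay, although the uncertainty is wide. The expected outcome is a step of a 1.4-fold higher number from compound 1 to compound 4 (0.14 log units; within the scatter). For compound 4 the estimate is 1800 nM, with an expected range of 500 nM to 7000 nM.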

Compound 4, concentration for 50% growth inhibition: 100 nM
For compound 4 the middle estimate is 18-fold (1.26 log units) above the measured one; measured number outside the range, below it.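

The earlier compounds shown here changed only the ester, and each of those steps weakened growth inhibition. Among these compounds, the change from 3-methoxyphenyl to 3-methylphenyl is the first step to strengthen it, giving a 13-fold lower number from compound 1 to compound 4 (1.11 log units; beyond the scatter) in this assay, so this place on the aromatic ring, meta to a large group, strongly affects potency, and replacing the methoxy group with a methyl group is favourable here. The swap removes one heavy atom and one hydrogen-bond acceptor, but nothing shown establishes which of these differences, if either, accounts for the gain.

From the compounds shown here alone, it remains open whether an amine, a chlorine atom or a longer chain at the same place would match the methyl group. Also unresolved is whether the 3-methylphenyl group would restore activity when paired with the larger esters of compound 2 and compound 3.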